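Sulfonyl sulfur swap: from compound 1 to compound 3

The source may report more compounds than this note shows. Statements on the series, on what has been measured and on what is new or still open speak of the compounds shown alone.

Measured in a functional assay on THP-1 cells (Homo sapiens) for activation, with a stated time of 18 h; a lower number here means that less compound is needed, a higher number that more compound is needed for the effect:
compound 1 `CC(C)(C)OC(=O)n1c(-c2ccc3c(c2)CC(NS(=O)(=O)c2c(F)cccc2F)C3)cc2ccccc21`: 210 nM
compound 2 `CC(C)(C)OC(=O)n1c(-c2ccc3c(c2)CC(NS(=O)(=O)c2cccs2)C3)cc2ccccc21`: 570 nM

Compound 1 has the lower number of the two measured compounds in this assay. Compound 3 `CC(C)(C)OC(=O)n1c(-c2ccc3c(c2)CC(NS(=O)(=O)c2ccc(-c4ccon4)s2)C3)cc2ccccc21` is unmeasured and differs from compound 1 as follows: 5-(1,2-oxazol-3-yl)thiophen-2-yl in place of 2,6-difluorophenyl on a sulfonyl sulfur. In words, this is 5-(1,2-oxazol-3-yl)thiophen-2-yl in place of 2,6-difluorophenyl on a sulfonyl sulfur. Going by the values given here, the one measured step on that sulfur is a 2.7-fold higher number from compound 1 to compound 2 (0.43 log units; beyond the scatter), modest and beyond the scatter. Among the compounds with values here, no measured compound carries the entering group, so a similar modest rise is expected, with wide uncertainty. The expected step is a 2.1-fold higher number from compound 1 to compound 3 (0.33 log units; beyond the scatter). The estimate for compound 3 is 450 nM, with an expected range of 130 nM to 1500 nM.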

Compound 3, half-maximal effective concentration: 590 nM
The estimate for compound 3 lay 1.3-fold (0.12 log units) below the measured number; measured number inside the range.
By their numbers in this assay, from the lowest: compound 1; then compounds 2 and 3 (each within the scatter of the next).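

In this assay, 1,2-oxazol-3-yl on the aromatic carbon of the thiophen-2-yl group gives a 1.0-fold higher number from compound 2 to compound 3 (0.01 log units; within the scatter), so this group and hydrogen are not told apart there. With a 2.8-fold higher number from compound 1 to compound 3 (0.45 log units; beyond the scatter), the larger 5-(1,2-oxazol-3-yl)thiophen-2-yl group on the sulfonyl sulfur still leaves 2,6-difluorophenyl with the lowest number of the three. No evidence on the cause of either step is available.

Open, from the compounds shown here alone, is whether a carboxylic acid or an aminomethyl group on that same aromatic carbon would also match hydrogen. Also open, going by these compounds, is whether a plain phenyl group would match 2,6-difluorophenyl.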